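Adding a methylfuran ring beside a retained trimethylpropyl chain

This account rests on a few compounds, and the source may have more. Where it says the series, first, only, none or still open, it means among the compounds named here.

Measured compounds:
Compound 1 `C[C@H](Nc1n[s+]([O-])nc1Nc1cccc(C(=O)N(C)C)c1O)C(C)(C)C` gives 484 nM in an assay on isolated protein for binding affinity to C-X-C chemokine receptor type 1 (Homo sapiens); on this read-out higher numbers stand for weaker inhibition and lower numbers for stronger inhibition.
Compound 2 `CC[C@@H](Nc1n[s+]([O-])nc1Nc1cccc(C(=O)N(C)C)c1O)c1ccccc1` gives 1220 nM in this assay.

Among the two measured compounds, compound 1 stands with the lowest number, and its nearest neighbour is compound 2, which lies a 2.5-fold higher number from compound 1 to compound 2 (0.40 log units; beyond the scatter) away. Compound 3 `Cc1ccc([C@H](Nc2n[s+]([O-])nc2Nc2cccc(C(=O)N(C)C)c2O)C(C)(C)C)o1` is not yet measured. It differs from compound 1 by 5-methylfuran-2-yl in place of methyl on a saturated chain carbon bound to a nitrogen on an aromatic ring and a saturated chain carbon.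

Among the measured compounds shown here, the one step with some bearing on this change is the one from compound 1 to compound 2, which placed 1-phenylpropyl in place of 1,2,2-trimethylpropyl on a nitrogen on an aromatic ring and was a 2.5-fold higher number from compound 1 to compound 2 (0.40 log units; beyond the scatter). That step exchanged the whole chain, whereas compound 3 keeps the trimethylpropyl carbons and only puts an aromatic ring where a methyl stood, so the comparison is loose. Taking the single measured step as the only guide, a step of modest size toward a higher number is expected. The step from compound 1 to compound 3 is estimated to be a 1.8-fold higher number from compound 1 to compound 3 (0.24 log units; within the scatter). Compound 3 is therefore expected to give 850 nM, with a range from 300 nM to 2500 nM.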

Compound 3, inhibition constant: 38 nM
The estimate for compound 3 lay 22-fold (1.35 log units) above the measured number; measured number outside the range, below it.
By their numbers in this assay, from the lowest: compound 3; then compound 1; then compound 2.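

Putting 5-methylfuran-2-yl in place of methyl on a saturated chain carbon bound to a nitrogen on an aromatic ring and a saturated chain carbon gave a 13-fold lower number from compound 1 to compound 3 (1.11 log units; beyond the scatter) in this assay and so showed that this carbon can carry an aromatic ring with a large move toward stronger inhibition. The earlier step, a 2.5-fold higher number from compound 1 to compound 2 (0.40 log units; beyond the scatter), exchanged the whole chain and could not show what a ring does on this carbon while the trimethylpropyl carbons stay in place. Nothing in the data accounts for the size of the new step.

The compounds shown leave open whether the methyl on the furan ring takes part in this step, as plain furan-2-yl would tell, and whether the ring oxygen does, as thiophen-2-yl or phenyl on the same carbon would tell. They also leave open whether an ethyl or a longer chain on this carbon, with no ring at all, would move the number in the same direction.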